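Replacing 2-bromophenyl with 2-chloro-5-fluorophenyl: working notes

The source may hold more compounds than are shown below. What is called first, only, known or untested is meant among the compounds shown, and "the series" means these compounds.

For the measured compounds named here, in an in vitro ADME assay on microsomes from liver (Rattus norvegicus) for metabolic stability, read by LC-MS (on this read-out lower numbers stand for a shorter-lived compound and higher numbers for a longer-lived compound), compound 2 (`Cn1c(=O)cc(N2CCC[C@@H](N)C2)n(Cc2ccccc2Br)c1=O`) gives 1.37 h as the only exact number so far. Compound 1 (`N[C@@H]1CCCN(c2cc(=O)[nH]c(=O)n2Cc2ccccc2Br)C1`) gives only a limit in this assay (> 1.96 h).

The next structure is compound 3 (`Cn1c(=O)cc(N2CCC[C@@H](N)C2)n(Cc2cc(F)ccc2Cl)c1=O`), which carries 2-chloro-5-fluorophenyl in place of 2-bromophenyl on a saturated chain carbon bound to an aromatic nitrogen in its structure. Going by the values given here, the one measured step is methyl in place of hydrogen on an aromatic nitrogen, which shows an at least 1.4-fold lower number from compound 1 to compound 2 (0.15 log units; that floor lies within the scatter) in the series. Its size is only a floor, with the limit of > 1.96 h in this assay, at which 1 of the 2 values shown sits, behind it. Among the compounds with values here, that step leaves the 2-bromophenyl group untouched, and no measured step changes this group, so it bears only weakly on the new change.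

No step beyond the scatter is therefore expected, and no direction is favoured. The expected step is a 1.0-fold higher number from compound 2 to compound 3 (0.01 log units; within the scatter) in this assay as an estimate. Compound 3 is estimated at 1.4 h and is expected to fall from 0.7 h to 2.8 h as its range.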

Compound 3, half-life: 0.883 h
For compound 3 the middle estimate is 1.6-fold (0.20 log units) above the measured one; low and high end bracket the measured number.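

In this assay, for the compounds shown here, the replacement of 2-bromophenyl by 2-chloro-5-fluorophenyl gives a 1.6-fold lower number from compound 2 to compound 3 (0.19 log units; within the scatter) as the first measured change at this position. On a saturated chain carbon bound to an aromatic nitrogen, this exchange of one halogen-bearing phenyl group for another therefore stays inside the scatter of the read-out, with the rest of the molecule held constant. Nothing measured here gives a cause for this step.

The compounds shown leave open how an unsubstituted phenyl group, or a phenyl group bearing a nitrile, would read at this place, so the contributions of the chlorine and the fluorine cannot be separated. Also open, on these data alone, is whether 2-chloro-5-fluorophenyl would read the same way on the core of compound 1, which keeps the hydrogen on the aromatic nitrogen.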